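A Cyclohexyloxy Group in Place of Butyl

The compounds below may be only part of what the source reports. "The series", "measured", "known", "first", "only" and "open" are said of these compounds alone.

Compound 1 `CCCCc1ccc2ncc(-c3nn[nH]n3)cc2c1` is one of three compounds tested in a functional assay on the whole organism (strain Sprague-Dawley) for inhibition, with Rattus norvegicus as the target; on this read-out higher numbers stand for an effect only at larger amounts of compound and lower numbers for an effect already at smaller amounts. In this assay compound 1 gives > 25 mg/kg, which is a limit of the assay rather than a measured number. Compound 2 `O=c1c(-c2nn[nH]n2)c[nH]c2ccc(F)cc12` also reaches only a limit, at > 20 mg/kg. Compound 3 `Cc1cccc2cc(C(=O)O)cnc12` gives > 25 mg/kg, again a limit. Going by the values given here, every value known so far is therefore a limit: the limit of > 25 mg/kg in this assay, at which 2 of the 3 values shown sit, holds two of them and the limit of > 20 mg/kg in this assay, at which 1 of the 3 values shown sits, holds the third. Among the compounds with values here, compound 1 stands at a limit like the others, so no order among the three compounds can be drawn, and no pair of them forms a measured step.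

Compound 4 `c1cc2ncc(-c3nn[nH]n3)cc2cc1OC1CCCCC1` has not yet been measured. It differs from compound 1 in a single place: cyclohexyloxy in place of butyl on an aromatic carbon. The new group sits on an aromatic carbon of a six-membered aromatic ring of carbon only, within the fused two-ring part of the shared core.

Within the data shown here, with no measured step available and all three known values sitting at limits, the expected step is a number no higher from compound 1 to compound 4 (the limit leaves the size open), which amounts to no change beyond the scatter. Compound 4 is therefore expected to give about 25 mg/kg, within a range from 10 mg/kg to 60 mg/kg, and the assay will most likely again report only a limit.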

Compound 4, minimum effective dose: 10 mg/kg
Estimate against measurement, compound 4: 2.5-fold (0.40 log units) above; the range from low to high includes it.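

Cyclohexyloxy in place of butyl on this aromatic carbon of the shared core gives an at least 2.5-fold lower number from compound 1 to compound 4 (0.39 log units; beyond the scatter), which makes compound 4 the only compound shown so far with a measured minimum effective dose rather than a limit. This position can therefore tell substituents apart in the whole animal: what sits on this carbon can decide whether an effect appears at a dose that can be read at all. The true size of the step remains unknown because compound 1 sits at a limit, so the step gives only a smallest possible size: the limit of > 25 mg/kg in this assay, at which 2 of the 4 values shown sit.

The change replaces an open chain with a ring and also adds an oxygen, so the compounds shown cannot say which of these matters, whereas a cyclohexyl group without the oxygen and a butoxy chain with the oxygen but no ring would pull the two apart. They also leave open how far the trend extends on this same carbon, for instance to a larger cycloheptyloxy ring, a smaller cyclopentyloxy ring or an amine.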